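Cytotoxicity notes: moving the chlorine in compound 1

This account rests on a few compounds, and the source may have more. Where it says the series, first, only, none or still open, it means among the compounds named here.

Compound 1 `O=C1CSC(c2ccc(Cl)cc2)N1CCN1CCCCC1` is the reference point of this small series. In an ADME assay on Vero cells (Chlorocebus sabaeus) for cytotoxicity, read by neutral red uptake, tested at 98 ug/mL (a higher number here means a weaker effect of the compound at the concentration tested, a lower number a stronger effect), compound 1 gives 74%, the lowest number of the three measured values. Its nearest neighbour on the numbers is compound 3 `O=C1CSC(c2ccc(O)cc2)N1CCN1CCCCC1`, which in this assay gives 94%; the step from a number 20 percentage points higher from compound 1 to compound 3 (beyond the scatter) separates the two. For the measured compounds named here, the furthest is compound 2 `COc1ccccc1C1SCC(=O)N1CCN1CCCCC1`, which in this assay gives 100%, and no single-place step connects compound 2 to compound 1, so only the two values themselves stand there.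

Compound 4 `O=C1CSC(c2cccc(Cl)c2)N1CCN1CCCCC1` has not been measured in this assay. Its difference from compound 1 is the following: 3-chlorophenyl in place of 4-chlorophenyl on a saturated ring carbon

Going by the values given here, none of the measured steps exchanges one chlorophenyl for another, so no step bears directly on this change. Among the compounds with values here, the one step that touches the same aryl group, from a number 20 percentage points higher from compound 1 to compound 3 (beyond the scatter), replaces the chlorine altogether and is modest. With the atoms kept and only rearranged, the step from a number 8 percentage points higher from compound 1 to compound 4 (within the scatter) is expected to be small, probably within the scatter, if anything toward a higher number. The value for compound 4 in this assay is therefore estimated at 82%, with a range from 62% to 100%.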

Compound 4, a percentage reported as activity, at one concentration (the size of the read-out at that concentration, not a potency): 100%
Estimate against measurement, compound 4: 18 percentage points below; low and high end bracket the measured number.
By their numbers in this assay, from the lowest: compound 1; then compounds 3, 2 and 4 (each within the scatter of the next).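

For the compounds shown here, the shift of the chlorine alone, with the same atoms kept, moves the reading in this assay: 3-chlorophenyl in place of 4-chlorophenyl gives a number 26 percentage points higher from compound 1 to compound 4 (beyond the scatter), a change the earlier compounds could not show, since their one step replaced the chlorine altogether. The other new comparison gives a number 6 percentage points higher from compound 3 to compound 4 (within the scatter), so this read-out does not separate 3-chlorophenyl from 4-hydroxyphenyl on this saturated ring carbon. Among the compounds shown, the low number therefore belongs to 4-chlorophenyl specifically and not to chlorophenyl as such, and no compound here goes against that. Nothing available accounts for the difference between the two chlorophenyl groups.

Open, on these data alone, is whether the low number depends on chlorine itself or would also appear with another group at the same place on the aryl ring, such as 4-bromophenyl, 4-fluorophenyl or 4-aminophenyl. Also open, as far as these compounds go, is how 2-chlorophenyl would read on this saturated ring carbon, which would show whether 4-chlorophenyl remains alone among the chlorophenyl groups.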